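Methyl to Chloro Swap on Two Related Side Chains

The source may report more compounds than this note shows. Statements on the series, on what has been measured and on what is new or still open speak of the compounds shown alone.

Measured compounds:
Compound 1, `Cc1cc(-n2cc(C(=O)Nc3cc(F)cc(F)c3)c(=O)c3ccc(N(C)C)nc32)ccc1OCCCCCCC[N+]12CCN(CC1)CC2`, gives 20.8%.
Compound 2, `CN(C)c1ccc2c(=O)c(C(=O)Nc3cc(F)cc(F)c3)cn(-c3ccc(OCCCCCCC[N+]45CCN(CC4)CC5)c(Cl)c3)c2n1`, gives 20.5%.
Compound 3, `Cc1cc(OCCCCCCC[N+]2(C)CCN(C)CC2)ccc1-n1cc(C(=O)Nc2cc(F)cc(F)c2)c(=O)c2ccc(N(C)C)nc21`, was reported as "not active" (no number reported), with no number given.

All three were tested in an assay on LX2 cells for inhibition of COL1A1 promoter (Homo sapiens), read by a luciferase reporter, with a stated time of 24 h, tested at 50 uM; on this read-out higher numbers stand for a stronger effect at the one concentration tested and lower numbers for a weaker effect. In this assay compound 1 gives 20.8% and compound 2 gives 20.5%. The two differ in one place: chloro in place of methyl on an aromatic carbon. The step of a number 0.3 percentage points lower from compound 1 to compound 2 (within the scatter) shows that this exchange left the read-out essentially where it was. Compound 3 carries a different side chain from compound 1; the difference between the two cores is not broken down here. Compound 3 showed no measurable effect in this assay and was recorded as not active.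

Compound 4, `CN1CC[N+](C)(CCCCCCCOc2ccc(-n3cc(C(=O)Nc4cc(F)cc(F)c4)c(=O)c4ccc(N(C)C)nc43)c(Cl)c2)CC1`, has not yet been measured. It differs from compound 3 in exactly one place: chloro in place of methyl on an aromatic carbon. Within the data shown here, the surroundings of the change are described in the same words for both pairs, so this is the same change as the one from compound 1 to compound 2. That earlier step was within the scatter, and the starting point, compound 3, gave no effect. The expectation is therefore a weak read-out for compound 4, since a change that did not move the result once is not expected to lift an inactive compound. Compound 4 is estimated to give 5%, with a likely range from -10% to 20%, and a fair chance it is again simply recorded as not active.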

Compound 4, a percentage reported as inhibition, at one concentration (the size of the read-out at that concentration, not a potency): "not active" (no number reported)
The entry for compound 4 holds no number, and the estimate cannot be compared.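

No step can be read between these two compounds: compound 3 is entered as "not active" (no number reported) and compound 4 as "not active" (no number reported). Nothing in the data shown bears on this result. These compounds leave open whether chloro in place of methyl changes the read-out at all on this side chain, given that neither compound has a number to compare.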